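Swapping the Amide Aryl Group: Nitro to Trimethoxy

This account rests on a few compounds, and the source may have more. Where it says the series, first, only, none or still open, it means among the compounds named here.

Of the compounds shown here, three sharing one core have been tested in a functional assay on Ehrlich cells (Mus musculus) for cytotoxicity, read by trypan blue exclusion, with a stated time of 2 h, tested at 100 ug/mL; on this read-out lower numbers stand for a weaker effect and higher numbers for a stronger effect at the one concentration tested. Compound 1 `CC(Cl)CC(=O)NC1=C(C#N)C(c2ccc(Cl)cc2Cl)C2=C(CCCC2=O)N1c1ccc(S(N)(=O)=O)cc1` carries a 2-chloropropyl group on the carbonyl carbon and gives 60%. Compound 2 `Cc1ccc(C(=O)NC2=C(C#N)C(c3ccc(Cl)cc3Cl)C3=C(CCCC3=O)N2c2ccc(S(N)(=O)=O)cc2)cc1`, with 4-methylphenyl there instead, gives 40%, and compound 3 `N#CC1=C(NC(=O)c2ccc([N+](=O)[O-])cc2)N(c2ccc(S(N)(=O)=O)cc2)C2=C(C(=O)CCC2)C1c1ccc(Cl)cc1Cl`, with 4-nitrophenyl, gives 70%. Compound 3 thus shows the top number of the three, yet the step of a number 10 percentage points higher from compound 1 to compound 3 (within the scatter) means it cannot be told apart from compound 1, while the step of a number 30 percentage points higher from compound 2 to compound 3 (beyond the scatter) sets it clearly above compound 2, just as a number 20 percentage points lower from compound 1 to compound 2 (beyond the scatter) does for compound 1.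

Compound 4 `COc1cc(C(=O)NC2=C(C#N)C(c3ccc(Cl)cc3Cl)C3=C(CCCC3=O)N2c2ccc(S(N)(=O)=O)cc2)cc(OC)c1OC` alters the same carbonyl position: 3,4,5-trimethoxyphenyl in place of 4-nitrophenyl on a carbonyl carbon. All three measured steps concern this one position and therefore bear on the change. Two of the three groups tried there gave numbers that cannot be separated, and one aryl group gave a clearly lower one, so a new aryl group could land anywhere in that span, and the data give no way to place it more exactly. Compound 4 is therefore expected to give about 50%, with a range from 30% to 70%. This amounts to an expected step of a number 20 percentage points lower from compound 3 to compound 4 (beyond the scatter), a modest fall that barely clears the scatter.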

Compound 4, a percentage reported as activity, at one concentration (the size of the read-out at that concentration, not a potency): 95%
Compound 4: middle estimate off by 45 percentage points, on the low side; measured number above the stated range.
By their numbers in this assay, from the lowest: compound 2; then compounds 1 and 3 (each within the scatter of the next); then compound 4.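

Changing one aryl group for another at this carbonyl carbon can lift the number well past anything the earlier groups reached: this assay shows a number 25 percentage points higher from compound 3 to compound 4 (beyond the scatter) on trading 4-nitrophenyl for 3,4,5-trimethoxyphenyl. The new group also stands clear of the other two, with a number 55 percentage points higher from compound 2 to compound 4 (beyond the scatter) against 4-methylphenyl and a number 35 percentage points higher from compound 1 to compound 4 (beyond the scatter) against 2-chloropropyl, so compound 4 is the only one of the four set apart from all the others. Aryl groups at this position now mark both ends of the series, with compound 2 at the bottom and compound 4 at the top, so having an aryl group there does not by itself settle the number.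

No evidence at hand explains this rise. From the compounds shown here alone, how a 4-methoxyphenyl, a 3,5-dimethoxyphenyl or a 4-aminophenyl group would compare at this carbonyl carbon remains open, and so does the question of whether all three methoxy groups are needed for the high number.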